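A few compounds are considered here, and "the series" means these few. Any claim that something is new, unique, unknown or untested is made for them only; others in the source may bear on it.

Measured compounds:
- compound 1, `O=c1cc(Cn2cc(CCO)nn2)c2ccc(O)cc2o1` — > 100000 nM
- compound 2, `O=c1cc(Cn2cc(CCCO)nn2)c2ccc(O)cc2o1` — > 100000 nM

In a functional assay on SW-620 cells (Homo sapiens) for inhibition, read by MTT assay, with a stated time of 72 h (a higher number here means a weaker inhibitor, a lower number a stronger inhibitor), compound 1 gives only a limit, > 100000 nM, not a number. In the same way compound 2 gives only a limit in this assay, > 100000 nM. Within the data shown here, compound 2 therefore stands at the limit, and the one other value shown is a limit as well (the limit of > 100000 nM in this assay, at which 2 of the 2 values shown sit). The step from compound 1 to compound 2, a step that the two limits leave unreadable from compound 1 to compound 2, is consequently unreadable in size.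

The next compound, compound 3, `O=c1cc(Cn2cc(CCCCO)nn2)c2ccc(O)cc2o1`, differs from compound 2 by hydroxymethyl in place of hydroxy on a saturated chain carbon, three bonds along the chain from an aromatic carbon. Among the measured compounds shown here, the only measured step that bears on this change is a step that the two limits leave unreadable from compound 1 to compound 2, which the two limits leave without a readable size or direction, so no step beyond the scatter can be predicted for this assay; the expectation is that compound 3 remains at the limit, which would be a step that the limit leaves unreadable from compound 2 to compound 3. For compound 3 the estimate in this assay is 150000 nM, with a range from 50000 nM to 600000 nM.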

Compound 3, half-maximal inhibitory concentration: > 100000 nM
Compound 3: a limit, no number; the forecaster's own chance of this, stated with the estimate: 85%; the middle value is on the limit's open side.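

In this assay compound 3 gives > 100000 nM as a limit, not a number. The steps among compound 1, compound 2 and compound 3 therefore cannot be read. The compounds shown leave open whether any hydroxy-ending chain on the shared core gives a measurable half-maximal inhibitory concentration: the limit of > 100000 nM in this assay, at which 3 of the 3 values shown sit.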